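Three bis-heteroaryl pyridines in the ovarian cell assay

This account rests on a few compounds, and the source may have more. Where it says the series, first, only, none or still open, it means among the compounds named here.

Compound 2 `C(=C/c1ccco1)\c1cc(-c2ccco2)cc(-c2cccs2)n1` gives 118000 nM in a functional assay on SK-OV-3 cells (Female gonad, Homo sapiens) for antiproliferative activity (on this read-out lower numbers stand for an effect already at smaller amounts and higher numbers for an effect only at larger amounts of compound), level with compound 1 `c1ccc(-c2cc(-c3cccs3)nc(-c3cccs3)c2)nc1` at the digits recorded, and compound 1 in this assay gives 118000 nM. The two values lie within the scatter of each other. The move to compound 3 `c1coc(-c2cc(-c3cccs3)nc(-c3cccs3)c2)c1` is thiophen-2-yl in place of 2-(furan-2-yl)ethenyl on an aromatic carbon. Among the compounds with values here, no measured pair on the shared core isolates this exchange, so the data give no direction for it. Compound 3 is expected at 118000 nM, with a range from 60000 nM to 240000 nM. The expected step of no change at the digits printed from compound 2 to compound 3 (within the scatter) is none beyond the scatter.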

Compound 3, half-maximal effective concentration: 118000 nM
Beside the measured number, compound 3's estimate shows no gap at the digits printed; the range from low to high includes it.
By their numbers in this assay, from the lowest: compounds 1, 2 and 3 (each within the scatter of the next).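

Within the data shown here, on the aromatic carbon next to the ring nitrogen, thiophen-2-yl in place of 2-(furan-2-yl)ethenyl gives no change at the digits printed from compound 2 to compound 3 (within the scatter) in this assay, the first measured pair for this exchange. Furan-2-yl in place of pyridin-2-yl on an aromatic carbon likewise gives no change at the digits printed from compound 1 to compound 3 (within the scatter), so neither exchange separates the compounds on this read-out. No supporting data explain this result.

Open, going by these compounds, is whether an amine or a carboxylic acid next to the ring nitrogen would move the value away from this shared level.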